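Removing One Fluorine from a Compound at the Assay Limit

A few compounds are considered here, and "the series" means these few. Any claim that something is new, unique, unknown or untested is made for them only; others in the source may bear on it.

The shared core of this series is seen in compound 1 `CCOC(=O)C1=Cc2ccccc2OC1(OCc1cc(-c2ccc(F)cc2F)no1)C(F)(F)F` and in compound 2 `CCCCCCCCn1cc(COC2(C(F)(F)F)Oc3ccccc3C=C2C(=O)OCC)nn1`. In a functional assay on MCF7 cells (Homo sapiens) for inhibition, read by MTT assay, with a stated time of 24 h (a lower number here means a stronger inhibitor, a higher number a weaker inhibitor), compound 1 gives only a limit of the assay, > 150000 nM. Compound 2 likewise gives only a limit, > 150000 nM. For the measured compounds named here, compound 1 thus stands at the limit of > 150000 nM in this assay, at which 2 of the 2 values shown sit, and no measured step between compounds is available. Compound 3 `CCOC(=O)C1=Cc2ccccc2OC1(OCc1cc(-c2ccc(F)cc2)no1)C(F)(F)F` has not yet been measured. It differs from compound 1 by hydrogen in place of fluoro on an aromatic carbon. With both values so far being limits, no size of step is shown. The change of hydrogen in place of fluoro on an aromatic carbon is expected to move the read-out by no more than the scatter, in neither direction. Compound 3 is expected to give 200000 nM, between 60000 nM and 600000 nM, most probably again only as a limit. The step from compound 1 to compound 3 is estimated as a step that the limit leaves unreadable from compound 1 to compound 3.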

Compound 3, half-maximal inhibitory concentration: 48200 nM
Estimate against measurement, compound 3: 4.1-fold (0.62 log units) above, and the stated range ends above it.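

Replacing 2,4-difluorophenyl with 4-fluorophenyl on the shared core brings the first readable number into this assay, and the change gives an at least 3.1-fold lower number from compound 1 to compound 3 (0.49 log units; beyond the scatter). This shows that hydrogen in place of fluoro at this position, on an aromatic carbon ortho to a large group, matters in this assay, which the two earlier limits could not show. As far as these compounds go, the full size of the step remains unknown, since compound 1 gives only a limit: the limit of > 150000 nM in this assay, at which 2 of the 3 values shown sit.

The compounds shown leave open whether a chlorine, a methoxy group or an amine at this same place would give a lower or a higher number than hydrogen. They also leave open whether a plain phenyl, with no fluoro group at all, would keep the number of compound 3.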